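The source may hold more compounds than are shown below. What is called first, only, known or untested is meant among the compounds shown, and "the series" means these compounds.

Of the compounds shown here, three built on one shared core have been measured in a functional assay on OVCAR-4 cells (Homo sapiens) for inhibition, read by sulforhodamine B assay, with a stated time of 48 h; a lower number here means a stronger inhibitor of growth, a higher number a weaker inhibitor of growth. Compound 1 `COc1cc(-c2nn(-c3cccc(NC(=O)Nc4cc(C(F)(F)F)cc(C(F)(F)F)c4)c3)cc2-c2ccncc2)ccc1Cl` gives 1120 nM. Compound 2 `COc1cc(-c2nn(-c3cccc(NC(=O)c4cccc(C(F)(F)F)c4)c3)cc2-c2ccncc2)ccc1Cl` gives 2280 nM. Compound 3 `COc1cc(-c2nn(-c3cccc(NC(=O)Nc4ccc(Cl)c(Cl)c4)c3)cc2-c2ccncc2)ccc1Cl` gives 1290 nM. On these numbers compound 3 stands second highest of the three; its nearest neighbour is compound 1 and its furthest is compound 2, and both lie within the usual scatter of it. Compound 4 `COc1cc(-c2nn(-c3cccc(NC(=O)Nc4cccc(C(F)(F)F)c4)c3)cc2-c2ccncc2)ccc1Cl` has not yet been measured. It differs from compound 3 in one place: 3-(trifluoromethyl)phenyl in place of 3,4-dichlorophenyl on an amide-type nitrogen. For the measured compounds named here, of the measured steps, only the one from compound 2 to compound 3 involves the same groups, a 1.8-fold lower number from compound 2 to compound 3 (0.25 log units; within the scatter), yet that exchange sits on the carbonyl carbon rather than on the amide-type nitrogen, so it bears only loosely. Compound 1 and compound 3, which carry different groups on that nitrogen, give values within the scatter of each other. A step of no size beyond the scatter is therefore expected, a 1.0-fold higher number from compound 3 to compound 4 (0.00 log units; within the scatter). For compound 4 in this assay the estimate is 1300 nM, with a range from 600 nM to 2800 nM.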

Compound 4, concentration for 50% growth inhibition: 1100 nM
Beside the measured number, compound 4's estimate is 1.2-fold (0.07 log units) above it, and the stated range covers the measured number.
By their numbers in this assay, from the lowest: compounds 4, 1, 3 and 2 (each within the scatter of the next, the first and the last beyond it).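

In this assay, 3-(trifluoromethyl)phenyl in place of 3,4-dichlorophenyl on the amide-type nitrogen gives a 1.2-fold lower number from compound 3 to compound 4 (0.07 log units; within the scatter), and hydrogen in place of one trifluoromethyl gives a 1.0-fold lower number from compound 1 to compound 4 (0.01 log units; within the scatter), so three differently substituted phenyl groups at this position cannot be told apart. For the compounds shown here, the one step beyond the scatter is modest: a 2.1-fold lower number from compound 2 to compound 4 (0.32 log units; beyond the scatter), where the 3-(trifluoromethyl)phenyl group stays and the amino link on the carbonyl carbon is what differs. This hints that the link counts for more here than the ring substituents, though a 1.8-fold lower number from compound 2 to compound 3 (0.25 log units; within the scatter), which also adds that link, stays within the scatter. As far as these compounds go, it remains open whether a cyclohexyl group, or a phenyl group carrying an amine or a carboxylic acid, on that nitrogen would hold these values. No available evidence bears on what lies behind these steps.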